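Changing the ester aryl group: from 4-hydroxyphenyl to 3-methoxyphenyl

The compounds below may be only part of what the source reports. "The series", "measured", "known", "first", "only" and "open" are said of these compounds alone.

Compound 1, `CC(=O)Oc1ccccc1C(=O)O[C@H]1CO[C@H]2[C@@H]1OC[C@H]2OC(=O)c1ccc(O)cc1`, gives 0.0198 h in an ADME assay on a cell-free system (plasma, Homo sapiens) for metabolic stability, with Plasma (Rattus norvegicus) as the target, read by HPLC, at pH 7.4; on this read-out lower numbers stand for a shorter-lived compound and higher numbers for a longer-lived compound.
Compound 2, `CC(=O)Oc1ccccc1C(=O)O[C@H]1CO[C@H]2[C@@H]1OC[C@H]2OC(=O)C1CC1`, gives 0.0322 h.

Among these two measured compounds, compound 1 shows the lowest number; its nearest neighbour is compound 2, and the step of a 1.6-fold higher number from compound 1 to compound 2 (0.21 log units; within the scatter) is too small to count as a real difference. Compound 3, `COc1cccc(C(=O)O[C@@H]2CO[C@H]3[C@@H]2OC[C@@H]3OC(=O)c2ccccc2OC(C)=O)c1`, has not been measured. It differs from compound 1 in one place: 3-methoxyphenyl in place of 4-hydroxyphenyl on a carbonyl carbon. Among the compounds with values here, the only measured step, a 1.6-fold higher number from compound 1 to compound 2 (0.21 log units; within the scatter), also replaces the 4-hydroxyphenyl group on the same carbonyl carbon, though with a different group, and it stayed inside the scatter. On that basis no step beyond the scatter is expected in this assay for compound 3. The expected step is a 1.3-fold higher number from compound 1 to compound 3 (0.10 log units; within the scatter). Compound 3 is therefore estimated at 0.025 h, with a likely range from 0.012 h to 0.055 h.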

Compound 3, half-life: 0.0525 h
Estimate against measurement, compound 3: 2.1-fold (0.32 log units) below, and the stated range covers the measured number.
By their numbers in this assay, from the lowest: compounds 1, 2 and 3 (each within the scatter of the next, the first and the last beyond it).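

Replacing 4-hydroxyphenyl with 3-methoxyphenyl on this carbonyl carbon gives, in this assay, a 2.7-fold higher number from compound 1 to compound 3 (0.42 log units; beyond the scatter), so this position can shift the half-life beyond the usual scatter, which the cyclopropyl change had not shown. The other step at this position, a 1.6-fold higher number from compound 2 to compound 3 (0.21 log units; within the scatter), stays within the scatter, so the cyclopropyl and 3-methoxyphenyl compounds cannot be told apart here. No measured evidence is available to explain the step from the 4-hydroxyphenyl compound.

The compounds shown do not reveal whether the longer half-life goes with losing the hydroxy group, gaining the methoxy group or the different placement on the ring. From the compounds shown here alone, how an amine, a carboxylic acid or a longer chain on this carbonyl carbon would behave also remains open.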